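Cytotoxicity near the assay limit: replacing the 2,4-difluorobenzyl group

The source may hold more compounds than are shown below. What is called first, only, known or untested is meant among the compounds shown, and "the series" means these compounds.

In a toxicity assay on MT2 cells (Homo sapiens) for cytotoxicity (a lower number here means that less compound is tolerated, a higher number that more compound is tolerated), compound 3 `Cc1nc(C)c([C@H](OC(C)(C)C)C(=O)O)c(N2CCC(C)(C)CC2)c1-c1ccc2c(c1)CCN(Cc1ccc(F)cc1F)C2` gives >= 24000 nM, which is a limit and not a number. Compound 2 `Cc1cccc(F)c1CN1CCc2cc(-c3c(C)nc(C)c([C@H](OC(C)(C)C)C(=O)O)c3N3CCC(C)(C)CC3)ccc2C1` gives >= 24000 nM, also a limit. Among the measured compounds shown here, compound 1 `Cc1cccc(Cl)c1CN1CCc2cc(-c3c(C)nc(C)c([C@H](OC(C)(C)C)C(=O)O)c3N3CCC(C)(C)CC3)ccc2C1` gives 22500 nM, the only actual number in the set. The data are therefore dominated by the limit of >= 24000 nM in this assay, at which 2 of the 3 values shown sit.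

Compound 4 `Cc1nc(C)c([C@H](OC(C)(C)C)C(=O)O)c(N2CCC(C)(C)CC2)c1-c1ccc2c(c1)CCN(c1nc3cnccc3s1)C2` differs from compound 3 on an amine nitrogen in a ring: a group of 9 heavy atoms (6 carbon, 2 nitrogen, 1 sulfur; one five-membered aromatic ring with 2 hetero atoms, one six-membered aromatic ring with 1 hetero atom) in place of a group of 9 heavy atoms (7 carbon, 2 fluorine; one six-membered aromatic ring of carbon only), on an amine nitrogen in a ring. The closest measured changes are at the same place. They are an at least 1.0-fold higher number from compound 1 to compound 2 (0.02 log units; that floor lies within the scatter) and an at least 1.0-fold higher number from compound 1 to compound 3 (0.02 log units; that floor lies within the scatter), while a step that the two limits leave unreadable from compound 2 to compound 3. For the measured compounds named here, no measured step brings a group with a five-membered aromatic ring to this nitrogen, so the evidence is indirect.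

On the basis of an at least 1.0-fold higher number from compound 1 to compound 3 (0.02 log units; that floor lies within the scatter), no shift beyond the scatter is expected in this assay. The expected step is an at least 1.2-fold lower number from compound 3 to compound 4 (0.07 log units; that floor lies within the scatter). For compound 4 the estimated value is 20000 nM, with an expected range of 8000 nM to 32000 nM.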

Compound 4, half-maximal cytotoxic concentration: >= 17000 nM
Compound 4: no number, only a limit; the forecaster's own chance of this, stated with the estimate: 50%; the middle value lies beyond the limit too.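

In this assay compound 4 gives >= 17000 nM, which is a limit and not a number. The steps to compound 4 from compound 1, compound 2 and compound 3 therefore cannot be read. The compounds shown leave open how much compound 4 is actually tolerated relative to these three.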